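A few compounds are considered here, and "the series" means these few. Any claim that something is new, unique, unknown or untested is made for them only; others in the source may bear on it.

Compound 1 `Cc1cc(C)c(Oc2nc(Nc3ccc(C#N)cc3)nc3ccccc23)c(C)c1` belongs to a small set of anilino-quinazoline ethers that were checked for how well human MT4 cells tolerate them. In an ADME assay on MT4 cells (Homo sapiens) for cytotoxicity, read by MTT assay, with a stated time of 4 days (a higher number here means that more compound is tolerated, a lower number that less compound is tolerated), compound 1 gives only a limit, > 34000 nM, and not a number. That reading sits at the limit of > 34000 nM in this assay, at which 1 of the 3 values shown sits, so compound 1 can only be placed as no more toxic than the limit allows, not ranked against the others. Two close relatives were measured fully. Compound 2 `Cc1cc(C#N)cc(C)c1Oc1nc(Nc2ccc(C#N)cc2)nc2ccc(Cl)cc12` gives 117000 nM in this assay. Compound 3 `CCOc1cc(C#N)cc(OCC)c1Oc1nc(Nc2ccc(C#N)cc2)nc2ccccc12` gives 108000 nM in this assay. These two values lie within the usual scatter of each other, so neither can be called the better tolerated of the pair.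

Compound 4 `N#Cc1ccc(Nc2nc(Oc3ccc(F)cc3)c3ccccc3n2)cc1` has not yet been measured. It differs from compound 1 in one place (4-fluorophenyl in place of 2,4,6-trimethylphenyl on an oxygen on an aromatic ring). Within the data shown here, no step between two measured compounds is available to show what such a swap does, so any expectation rests on the general picture that all three measured compounds are tolerated at high concentrations. On that basis the step from compound 1 to compound 4 is expected to be small, most likely no larger than the scatter, a step that the limit leaves unreadable from compound 1 to compound 4. Compound 4 is therefore estimated to give about 90000 nM in this assay, with a plausible range from 30000 nM to 200000 nM, and a fair chance that only a limit is reported.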

Compound 4, half-maximal cytotoxic concentration: > 351000 nM
Compound 4 was reported as a limit (the forecaster's own chance of this, stated with the estimate: 40%); middle value at least 3.9-fold (0.59 log units) away from the limit.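

Compound 4 gives > 351000 nM in this assay, which is a limit and not a number. Among these compounds, compound 1 is also known only as a limit, so no step from compound 1 to compound 4 can be read. The compounds shown leave open whether 4-fluorophenyl in place of 2,4,6-trimethylphenyl changes the tolerated concentration at all, and by how much.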